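This account rests on a few compounds, and the source may have more. Where it says the series, first, only, none or still open, it means among the compounds named here.

In a functional assay on MGC-803 cells (Homo sapiens) for antiproliferative activity, read by MTT assay, with a stated time of 72 h (a higher number here means a weaker inhibitor, a lower number a stronger inhibitor), compound 1 (`O=C1OCC[C@@H]1NC(=S)SCCOc1ccc([N+](=O)[O-])cc1`) gives > 100000 nM, which is a limit and not a measured number. Compound 2 (`CCCCCCCCCCSC(=S)N[C@H]1CCOC1=O`) gives > 64000 nM, also a limit. Compound 3 (`O=C(CNc1ccc(Br)cc1)N[C@H]1CCOC1=O`) gives > 64000 nM, again a limit. None of the three therefore has an exact value to rank it by.

Compound 4 (`CC(=O)c1ccc(OCCSC(=S)N[C@H]2CCOC2=O)cc1`) keeps the core of compound 1 but carries acetyl in place of nitro on an aromatic carbon, para to a large group: acetyl in place of nitro on an aromatic carbon. Among the measured compounds shown here, no measured pair shows what this swap does. With compound 1 at its limit of > 100000 nM, no step beyond the scatter is expected in this assay, in either direction. The expected step, an at least 1.2-fold lower number from compound 1 to compound 4 (0.09 log units; that floor lies within the scatter), is only an estimate. For compound 4 the estimated value is 80000 nM, with an expected range of 25000 nM to 160000 nM.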

Compound 4, half-maximal inhibitory concentration: > 64000 nM
Compound 4: no number, only a limit (the forecaster's own chance of this, stated with the estimate: 75%); the middle value lies beyond the limit too.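

Among the compounds shown here, compound 1 and compound 4 each give only a limit and not a number, so no step between them can be read. Whether acetyl in place of nitro changes the result in this assay stays open, as does any ranking of the compounds shown.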